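From 3-(methoxymethoxy)phenyl to 4-bromophenyl at the chain end

The source may hold more compounds than are shown below. What is called first, only, known or untested is meant among the compounds shown, and "the series" means these compounds.

- Compound 1 `COc1cccc(/C=C/CCCOc2cc(/C=C\c3cc(OC)c(OC)c(OC)c3)ccc2OC)c1`: 25000 nM
- Compound 2 `COCOc1ccccc1/C=C/CCCOc1cc(/C=C\c2cc(OC)c(OC)c(OC)c2)ccc1OC`: 9600 nM
- Compound 3 `COCOc1cccc(/C=C/CCCOc2cc(/C=C\c3cc(OC)c(OC)c(OC)c3)ccc2OC)c1`: 59000 nM

These values come from a functional assay on HT-29 cells (Homo sapiens) for inhibition, read by MTT assay, with a stated time of 3 days; on this read-out lower numbers stand for stronger inhibition and higher numbers for weaker inhibition. Of the three, compound 3 gives the highest number, 59000 nM, which makes it the weakest so far. The next change gives compound 4 `COc1ccc(/C=C\c2cc(OC)c(OC)c(OC)c2)cc1OCCC/C=C/c1ccc(Br)cc1`, with 4-bromophenyl in place of 3-(methoxymethoxy)phenyl on a double-bonded chain carbon bound to a double-bonded chain carbon.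

Three measured steps alter this end of the molecule: a 2.6-fold lower number from compound 1 to compound 2 (0.42 log units; beyond the scatter), a 2.4-fold higher number from compound 1 to compound 3 (0.37 log units; beyond the scatter) and a 6.1-fold higher number from compound 2 to compound 3 (0.79 log units; beyond the scatter). All are modest, yet none involves bromine, so they offer only a rough guide. Compound 3 stands at the top of this small range, and the other two end groups both gave lower numbers, as compound 1 shows at 25000 nM. A modest fall in this assay is therefore expected, not a further rise. The expected change is a 2.4-fold lower number from compound 3 to compound 4 (0.37 log units; beyond the scatter). For compound 4 the estimated value is 25000 nM, with an expected range from 8000 nM to 70000 nM.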

Compound 4, half-maximal inhibitory concentration: 11000 nM
Estimate against measurement, compound 4: 2.3-fold (0.36 log units) above; measured number inside the range.
By their numbers in this assay, from the lowest: compounds 2 and 4 (each within the scatter of the next); then compound 1; then compound 3.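

Going by these compounds alone, this is the first end group with bromine and without oxygen, and in this assay 4-bromophenyl gives a 5.4-fold lower number from compound 3 to compound 4 (0.73 log units; beyond the scatter) and also a 2.3-fold lower number from compound 1 to compound 4 (0.36 log units; beyond the scatter) at this position. The remaining step, a 1.1-fold higher number from compound 2 to compound 4 (0.06 log units; within the scatter), lies within the scatter, so 2-(methoxymethoxy)phenyl and 4-bromophenyl cannot be told apart here. A methoxymethoxy group is therefore not needed to reach this level on the chain end, although compound 2 shows that one can reach it.

As far as these compounds go, whether 4-chlorophenyl, 4-aminophenyl, a carboxylic acid at the same place or a longer chain would move the number further remains open. Nothing measured here explains why the numbers shift with the end group.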